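Naphthalen-1-yl Replaced by 3-(Trifluoromethyl)benzyl: Permeability Outlook

The compounds below may be only part of what the source reports. "The series", "measured", "known", "first", "only" and "open" are said of these compounds alone.

Going by the values given here, compound 2 `COc1cccc(CNCCCNc2ccnc3cc(-c4cccc5ccccc45)ccc23)c1O` stands highest of the two numbers so far in an ADME assay for permeability, using PAMPA, with a stated time of 30 min, at pH 7.4 (on this read-out higher numbers stand for higher permeability and lower numbers for lower permeability), where compound 2 gives 237 10^-6 cm/s. Among the compounds with values here, its only neighbour is compound 1 `COc1cccc(CNCCCNc2ccnc3cc(Cc4ccc(F)cc4)ccc23)c1O`, and in this assay compound 1 gives 23 10^-6 cm/s. Within the data shown here, the single measured step, a 10-fold higher number from compound 1 to compound 2 (1.01 log units; beyond the scatter), separates the two compounds, and it is the only step that bears on the question at hand.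

Compound 3 `COc1cccc(CNCCCNc2ccnc3cc(Cc4cccc(C(F)(F)F)c4)ccc23)c1O` differs from compound 2 in one place: 3-(trifluoromethyl)benzyl in place of naphthalen-1-yl on an aromatic carbon. This change runs the measured step backwards in kind, since 3-(trifluoromethyl)benzyl, like 4-fluorobenzyl, is a single six-membered aromatic ring of carbon only joined through a methylene, while naphthalen-1-yl leaves. The two ends are not the same, so the size need not repeat exactly. The account therefore expects a downward step a 5.3-fold lower number from compound 2 to compound 3 (0.72 log units; beyond the scatter) in this assay, large and beyond the scatter, though perhaps not quite matching a 10-fold higher number from compound 1 to compound 2 (1.01 log units; beyond the scatter) in full. Compound 3 is expected to give 45 10^-6 cm/s in this assay, with a range from 15 10^-6 cm/s to 130 10^-6 cm/s.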

Compound 3, apparent permeability: 23 10^-6 cm/s
Compound 3: the middle estimate sits 2.0-fold (0.29 log units) above what was measured, and the stated range covers the measured number.
By their numbers in this assay, from the lowest: compounds 1 and 3 (each within the scatter of the next); then compound 2.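

In this assay, 3-(trifluoromethyl)benzyl in place of naphthalen-1-yl on this aromatic carbon takes the number back down (a 10-fold lower number from compound 2 to compound 3 (1.01 log units; beyond the scatter)), so the high number of compound 2 is now set against two benzyl-type groups rather than one. The two benzyl-type compounds do not separate, since 3-(trifluoromethyl)phenyl in place of 4-fluorophenyl on the saturated chain carbon gives (no change at the digits printed from compound 1 to compound 3 (within the scatter)), and among the three compounds only compound 2, with naphthalen-1-yl, stands apart. No measurement at hand accounts for this difference.

The change from compound 2 to compound 3 alters the ring count, the fluorine content and the saturated chain carbon together, so the compounds shown leave open which of these goes with the change in number. A naphthalen-1-ylmethyl group or a 3-(trifluoromethyl)phenyl group set directly on the same aromatic carbon would pull these apart, and a naphthalen-2-yl group would test whether the naphthalen-1-yl attachment itself matters.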